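Amide aryl replacement in an antiproliferative anilide series

This account rests on a few compounds, and the source may have more. Where it says the series, first, only, none or still open, it means among the compounds named here.

Three anilides sharing one core have been tested in a functional assay on MDA-MB-468 cells (Homo sapiens) for antiproliferative activity, read by MTT assay, with a stated time of 72 h; a higher number here means a weaker inhibitor, a lower number a stronger inhibitor. Compound 1 `Cc1nc(C(=O)Nc2ccc(Cl)c(-c3nnc4c(Cl)cccn34)c2)cs1` reaches only the assay limit, giving > 100000 nM. Compound 2 `O=C(Nc1ccc(Cl)c(-c2nnc3c(Cl)cccn23)c1)c1cccnc1` likewise sits at the limit, with > 100000 nM. For the measured compounds named here, compound 3 `O=C(Nc1ccc(Cl)c(-c2nnc3c(Cl)cccn23)c1)c1ccc(C(F)(F)F)cc1F` is the only member with a numerical read-out, giving 22300 nM. On the numbers shown, compound 2 therefore stands at the ceiling of this assay, alongside compound 1, and the limit of > 100000 nM in this assay, at which 2 of the 3 values shown sit, is all that describes its position. Going by the values given here, the single one-place step, a step that the two limits leave unreadable from compound 1 to compound 2, cannot be sized for the same reason.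

Compound 4 `O=C(Nc1ccc(Cl)c(-c2nnc3c(Cl)cccn23)c1)c1c(F)cccc1Cl` is not yet measured. It differs from compound 2 in that (2-chloro-6-fluorophenyl in place of pyridin-3-yl on a carbonyl carbon). Among the compounds with values here, no measured step matches this change, and the only relevant comparison is that compound 3, which also carries a substituted phenyl on the carbonyl carbon, gives a readable value where compound 2 does not. The change is therefore expected to move compound 4 off the limit, at most modestly, in the direction of stronger inhibition, with an at least 2.0-fold lower number from compound 2 to compound 4 (0.30 log units; that floor lies within the scatter) as the expected step. Compound 4 is estimated at 50000 nM in this assay, within a range of 15000 nM to 200000 nM.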

Compound 4, half-maximal inhibitory concentration: 57600 nM
Estimate against measurement, compound 4: 1.2-fold (0.06 log units) below, within the range that was stated.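

In this assay, the carbonyl carbon now carries a second substituted phenyl with a numerical read-out, as compound 4 gives 57600 nM. Replacing pyridin-3-yl with 2-chloro-6-fluorophenyl reads as an at least 1.7-fold lower number from compound 2 to compound 4 (0.23 log units; that floor lies within the scatter), and replacing 2-methyl-1,3-thiazol-4-yl with the same group reads as an at least 1.7-fold lower number from compound 1 to compound 4 (0.23 log units; that floor lies within the scatter); both figures are floors only, so neither step is established as exceeding the scatter. The true size of each step stays unknown because both starting compounds rest on a limit: the limit of > 100000 nM in this assay, at which 2 of the 4 values shown sit.

From the compounds shown here alone, it remains open whether the numerical read-outs depend on the phenyl ring itself or on the groups it carries, since compound 3 at 22300 nM and compound 4 at 57600 nM have no unsubstituted phenyl or single-chlorine phenyl to compare with. Also open, going by these compounds, is how a cyclohexyl group, or a phenyl bearing an amine or a carboxylic acid, on the same carbonyl carbon would read in this assay.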